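This account rests on a few compounds, and the source may have more. Where it says the series, first, only, none or still open, it means among the compounds named here.

Measured compounds:
compound 1, `Cc1cccc(C(=O)N2CCCC(C(=O)Nc3ccc(Cl)cc3)C2)c1`, 0%
compound 2, `O=C(Nc1cccc(Oc2ccccc2)c1)C1CCCN(C(=O)c2cccc(-c3ccco3)c2)C1`, 0%
compound 3, `O=C(Nc1cccc([N+](=O)[O-])c1)C1CCCN(C(=O)c2cc(C(F)(F)F)cc(C(F)(F)F)c2)C1`, 9%

In an ADME assay on PC-3 cells (Homo sapiens) for cytotoxicity, read by WST assay, tested at 100 uM (on this read-out higher numbers stand for more inhibition at the one concentration tested (going by the name of the read-out) and lower numbers for less inhibition), compound 3 gives 9%, and its gaps to compound 1 and to compound 2 both lie within the usual scatter of this read-out, so the three measured compounds cannot be told apart; all of them show little inhibition at the single concentration tested. Compound 4, `O=C(c1ccccc1)c1cccc(NC(=O)C2CCCN(C(=O)c3cc(C(F)(F)F)cc(C(F)(F)F)c3)C2)c1`, has not yet been measured. It differs from compound 3 in one place: benzoyl in place of nitro on an aromatic carbon.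

No pair of measured compounds differing in one place is available, so nothing shown here tells how an exchange at this position moves the number. Given that the three measured compounds, with different groups at the amide-bearing ring and at the other aryl ring, all sit close together, compound 4 is expected to stay with them, and the step of a number 4 percentage points lower from compound 3 to compound 4 (within the scatter) is expected to be none beyond the scatter. Compound 4 is therefore estimated at 5%, within a range from 0% to 25%.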

Compound 4, a percentage reported as inhibition, at one concentration (the size of the read-out at that concentration, not a potency): 0%
For compound 4 the middle estimate is 5 percentage points above the measured one, and the stated range covers the measured number.
By their numbers in this assay, from the lowest: compounds 1, 2, 4 and 3 (each within the scatter of the next).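

Among these compounds, putting benzoyl in place of nitro on an aromatic carbon, meta to a large group, gives a number 9 percentage points lower from compound 3 to compound 4 (within the scatter) and is the only exchange at one place that can be read in this assay. It shows that at this position, 8 heavy atoms with a six-membered aromatic ring can enter where 3 heavy atoms leave without moving the number beyond the scatter. Nothing measured here offers an explanation of this result.

On these data alone, whether an amine or a carboxylic acid on the same aromatic carbon would also stay within the scatter remains open. Among the compounds shown here, it is also open whether this exchange would read the same with the acyl group of compound 1 or compound 2 in place of the one shared by compound 3 and compound 4.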